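This account rests on a few compounds, and the source may have more. Where it says the series, first, only, none or still open, it means among the compounds named here.

Compound 1 `COc1ccc(N2CCN(Cc3csc(N)c3C(=O)c3ccc(Cl)cc3)CC2)cc1` is the starting point. For the measured compounds named here, in an assay on CHO cells for displacement of a labelled ligand from adenosine receptor A3 (Homo sapiens), read by scintillation counting, with a stated time of 120 min, tested at 10 uM (on this read-out lower numbers stand for less inhibition and higher numbers for more inhibition at the one concentration tested (going by the name of the read-out)), compound 1 gives 0%, which places it level with its only measured neighbour: compound 2 `Nc1scc(CN2CCN(CCCc3ccc(Cl)cc3)CC2)c1C(=O)c1ccc(Cl)cc1`, which in this assay gives 0%. Going by the values given here, the single measured step, no change at the digits printed from compound 1 to compound 2 (within the scatter), swaps the group on the ring amine nitrogen for a quite different one and leaves the read-out where it was.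

The unmeasured compound 3 `Nc1scc(CN2CCN(c3c(Cl)cccc3Cl)CC2)c1C(=O)c1ccc(Cl)cc1` changes compound 1 at that same place: 2,6-dichlorophenyl in place of 4-methoxyphenyl on an amine nitrogen in a ring. Among the compounds with values here, the one step that bears on this change, no change at the digits printed from compound 1 to compound 2 (within the scatter), altered the very same position of the shared core without any movement beyond the scatter, and both measured compounds sit at the bottom of the scale, so there is no sign yet that anything attached to this nitrogen lifts the read-out. The expectation for compound 3 is therefore no step beyond the scatter in this assay, so that a number 3 percentage points higher from compound 1 to compound 3 (within the scatter) is the estimated change. Compound 3 is estimated to give 3% in this assay, with a range from 0% to 18%.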

Compound 3, a percentage reported as inhibition, at one concentration (the size of the read-out at that concentration, not a potency): 1%
Beside the measured number, compound 3's estimate is 2 percentage points above it, and the stated range covers the measured number.
By their numbers in this assay, from the lowest: compounds 1, 2 and 3 (each within the scatter of the next).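

Putting 2,6-dichlorophenyl in place of 4-methoxyphenyl on the ring nitrogen gives a number 1 percentage points higher from compound 1 to compound 3 (within the scatter), and putting it in place of 3-(4-chlorophenyl)propyl gives a number 1 percentage points higher from compound 2 to compound 3 (within the scatter). This adds a new kind of group to the position: two chlorines and no hydrogen-bond acceptor, where 4-methoxyphenyl has an oxygen and one acceptor, yet in this assay all three compounds remain within the scatter of one another and near the bottom of the scale. No measurement shown here offers an explanation for this flat result.

What stays open is whether any group on this nitrogen can raise the read-out, since all three groups shown carry a six-membered aromatic ring of carbon only, and a chain ending in an amine or a carboxylic acid might read differently in this assay. The compounds shown also keep the shared core the same apart from this one position, so they leave unanswered whether a change elsewhere on it would move the number at all.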